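Swapping Nitro for Chloro on a Sulfonamide Benzamide

The source may report more compounds than this note shows. Statements on the series, on what has been measured and on what is new or still open speak of the compounds shown alone.

Measured compounds:
compound 1, `O=C(NCc1ccc(CNS(=O)(=O)c2ccccc2)cc1)c1ccc([N+](=O)[O-])cc1`, 100 nM
compound 2, `Cc1ccc(S(=O)(=O)NCc2ccc(CNC(=O)c3ccccc3F)cc2)cc1`, 1000 nM

In an assay on MDA-MB-231 cells for binding affinity to C-X-C chemokine receptor type 4 (Homo sapiens), read by immunofluorescence and microscopy, with stated times of 10 min and 30 min (a higher number here means that more compound is needed for the effect, a lower number that less compound is needed), compound 1 gives 100 nM. It holds the lowest number of the two measured compounds; the nearest, compound 2, gives 1000 nM, a gap beyond the scatter. Within the data shown here, no step between measured compounds that differ in one place has been recorded, so the effect of a single change on the shared core of compound 1 is not yet known.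

Compound 3, `O=C(NCc1ccc(CNS(=O)(=O)c2ccccc2)cc1)c1ccc(Cl)cc1`, has yet to be tested in this assay. It differs from compound 1 in one place: chloro in place of nitro on an aromatic carbon, on an aromatic carbon of a six-membered aromatic ring of carbon only, para to a large group.

Compound 3 is expected to give about 300 nM, within 60 nM to 1500 nM. The expected step of a 3.0-fold higher number from compound 1 to compound 3 (0.48 log units; beyond the scatter) is a modest weakening that may still fall within the scatter.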

Compound 3, effective concentration (reported as EC, without a stated level of effect): 100 nM
Compound 3: middle estimate off by 3.0-fold (0.48 log units), on the high side; the range from low to high includes it.
By their numbers in this assay, from the lowest: compounds 1 and 3 (each within the scatter of the next); then compound 2.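

In this assay, among these compounds, the first recorded single change on the shared core shows that this position, on an aromatic carbon para to a large group, accepts chloro in place of nitro, with no change at the digits printed from compound 1 to compound 3 (within the scatter) and the two compounds standing level. The number therefore holds when the nitro group and its hydrogen-bond acceptors leave and a single chlorine atom with no hydrogen-bond acceptor enters. Nothing at hand accounts for this result.

On these data alone, whether the position would accept other groups, such as an amine, a carboxylic acid or a methoxy group, remains open. As far as these compounds go, it is also open whether chloro in place of nitro would leave the number unchanged on a core that carries different groups elsewhere.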